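The compounds below may be only part of what the source reports. "The series", "measured", "known", "first", "only" and "open" are said of these compounds alone.

In a functional assay on MCF7 cells (Homo sapiens) for antiproliferative activity, read by MTT assay, with a stated time of 48 h; a lower number here means a stronger inhibitor, a higher number a weaker inhibitor:
- compound 1 `Cc1ccc(-c2nnc(NC(=O)/C=C/c3ccc(C(F)(F)F)cc3)s2)cc1`: 1.1 ug/mL
- compound 2 `O=C(/C=C/c1ccc(C(F)(F)F)cc1)Nc1nnc(-c2ccccc2)s1`: 1.52 ug/mL

The two measured numbers do not separate: a 1.4-fold higher number from compound 1 to compound 2 (0.14 log units; within the scatter). Among the compounds with values here, compound 2 therefore stands level with the only other measured compound. Compound 3 `O=C(/C=C/c1ccc(F)cc1)Nc1nnc(-c2ccccc2)s1` carries fluoro in place of trifluoromethyl on an aromatic carbon. Within the data shown here, the only measured step, a 1.4-fold higher number from compound 1 to compound 2 (0.14 log units; within the scatter), is hydrogen in place of methyl, a change elsewhere, so it bears on this change only indirectly. Among the measured compounds shown here, no measured step covers this exchange, and no shift beyond the scatter is expected in this assay. The estimated change is a 1.3-fold higher number from compound 2 to compound 3 (0.12 log units; within the scatter). For compound 3 the expected value is 2 ug/mL, with an estimated range of 0.8 ug/mL to 5 ug/mL.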

Compound 3, half-maximal inhibitory concentration: 1.45 ug/mL
Beside the measured number, compound 3's estimate is 1.4-fold (0.14 log units) above it; the range from low to high includes it.
By their numbers in this assay, from the lowest: compounds 1, 3 and 2 (each within the scatter of the next).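

In this assay fluoro in place of trifluoromethyl on an aromatic carbon para to a large group gives a 1.0-fold lower number from compound 2 to compound 3 (0.02 log units; within the scatter) and so no separation between the two compounds. Within the data shown here, this is the first reading at this position, since the earlier step, hydrogen in place of methyl, lay elsewhere, and it shows that this exchange leaves the number within the scatter. Nothing available bears on why the number holds here.

Still open, on these data alone, is whether an amine or a carboxylic acid at this position would also stay within the scatter, or would separate from compound 2 and compound 3.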